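Replacing chloro with hydrogen on compound 2

The source may report more compounds than this note shows. Statements on the series, on what has been measured and on what is new or still open speak of the compounds shown alone.

Measured so far in a functional assay on WM 266-4 cells (Homo sapiens) for antiproliferative activity, read by MTT assay, with a stated time of 24 h; on this read-out higher numbers stand for weaker inhibition of growth and lower numbers for stronger inhibition of growth:
- compound 1 `c1ccc(N2N=C(c3ccc4c(c3)OCCO4)CC2c2ccc3ccccc3c2)cc1` gives 13900 nM
- compound 2 `Clc1cccc(C2CC(c3ccc4c(c3)OCCO4)=NN2c2ccccc2)c1` gives 1750 nM

Compound 2 holds the lower of the two numbers, and so the stronger inhibition of growth. Compound 3 `c1ccc(C2CC(c3ccc4c(c3)OCCO4)=NN2c2ccccc2)cc1` has hydrogen in place of chloro on an aromatic carbon, meta to a large group (hydrogen in place of chloro on an aromatic carbon), so that 3-chlorophenyl becomes phenyl. Within the data shown here, no measured step covers this change directly. Among the measured compounds shown here, the one step available acts on the same group, 3-chlorophenyl in place of naphthalen-2-yl (a 7.9-fold lower number from compound 1 to compound 2 (0.90 log units; beyond the scatter)), and it is modest. It suggests that this group matters in this assay, but it does not fix the size of the loss of chloro. A smaller step towards a higher number is expected, at the edge of the scatter or a little beyond it. The expected step is a 2.0-fold higher number from compound 2 to compound 3 (0.30 log units; within the scatter) as an estimate. Compound 3 is estimated at 3500 nM (1400 nM to 9000 nM).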

Compound 3, concentration for 50% growth inhibition: 22400 nM
For compound 3 the middle estimate is 6.4-fold (0.81 log units) below the measured one; measured number outside the range, above it.
By their numbers in this assay, from the lowest: compound 2; then compounds 1 and 3 (each within the scatter of the next).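

In this assay, the loss of the chloro from the 3-chlorophenyl group is a large step on its own (a 13-fold higher number from compound 2 to compound 3 (1.11 log units; beyond the scatter)), so this one position on the aromatic ring strongly affects the read-out. Phenyl and naphthalen-2-yl on the saturated ring carbon are not separated (a 1.6-fold higher number from compound 1 to compound 3 (0.21 log units; within the scatter); within the scatter), so among these three compounds the stronger inhibition of growth goes with the 3-chlorophenyl group of compound 2 alone. Nothing at hand accounts for the effect of the chloro.

Going by these compounds, what a fluoro, a methoxy or an amine would give at this same place remains open. So does whether a chloro elsewhere on the ring would match compound 2.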